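Compound 3 to compound 4: the sulfonyl group replaced

The compounds below may be only part of what the source reports. "The series", "measured", "known", "first", "only" and "open" are said of these compounds alone.

In a functional assay on MV4-11 cells (Homo sapiens) for cytotoxicity, read by MTT assay, with a stated time of 72 h (on this read-out higher numbers stand for weaker inhibition and lower numbers for stronger inhibition), compound 1 `CCCS(=O)(=O)Nc1ccc(-c2cn3c(C(=O)OCC)csc3n2)cc1` gives > 20000 nM, a limit and not a number. Compound 2 `C=CC(=O)Nc1cccc(-c2cn3c(C(=O)OCC)csc3n2)c1`, which also carries vinylcarbonyl, gives > 20000 nM, again a limit. Compound 3 `CCOC(=O)c1csc2nc(-c3ccc(NS(=O)(=O)c4ccc(C)cc4)cc3)cn12` gives > 20000 nM, likewise a limit, so the series stands at the limit of > 20000 nM in this assay, at which 3 of the 3 values shown sit.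

Compound 4 `C=CC(=O)Nc1ccc(-c2cn3c(C(=O)OCC)csc3n2)cc1` has vinylcarbonyl in place of (4-methylphenyl)sulfonyl on a nitrogen on an aromatic ring. Going by the values given here, the one measured step bearing on this, a step that the two limits leave unreadable from compound 1 to compound 3, has no readable size, so no shift beyond the scatter in this assay is expected, in either direction. The expected step is a number no higher from compound 3 to compound 4 (the limit leaves the size open). Compound 4 is estimated at 20000 nM, with an expected range of 6000 nM to 40000 nM.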

Compound 4, half-maximal inhibitory concentration: 2930 nM
The estimate for compound 4 lay 6.8-fold (0.83 log units) above the measured number; measured number outside the range, below it.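

On the nitrogen on an aromatic ring, the group decides whether the series gives a readable number at all: vinylcarbonyl in place of a sulfonyl group gives an at least 6.8-fold lower number from compound 3 to compound 4 (0.83 log units; beyond the scatter) and an at least 6.8-fold lower number from compound 1 to compound 4 (0.83 log units; beyond the scatter). Compound 2 also carries vinylcarbonyl and gives > 20000 nM, a limit of the assay, so that group alone does not guarantee a number. Compound 4 alone leaves the limit: the limit of > 20000 nM in this assay, at which 3 of the 4 values shown sit.

The compounds shown leave open whether the double bond of vinylcarbonyl matters, which a propanoyl group on the same nitrogen would test.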